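Swapping Hexyl for Hexyloxy on a Modest Inhibitor

The source may hold more compounds than are shown below. What is called first, only, known or untested is meant among the compounds shown, and "the series" means these compounds.

In a functional assay on brain (Rattus norvegicus, strain Wistar) for inhibition (a lower number here means a stronger inhibitor, a higher number a weaker inhibitor), compound 1 `Cc1[nH]c(=O)n(C)c1-c1ccccc1` gives > 100000 nM as its reading, which is a limit of the assay and not a number. Compound 2 `CCCCCOc1ccc(-c2c(C)[nH]c(=O)n2C)cc1` gives 4500 nM as its value. Compound 3 `CCCCCCc1ccc(-c2c(C)[nH]c(=O)n2C)cc1` gives 9000 nM as its value, which places it level with compound 2, since the measured move a 2.0-fold higher number from compound 2 to compound 3 (0.30 log units; within the scatter) stays within the scatter. Adding pentyloxy or hexyl to the shared core made a large difference, seen in an at least 22-fold lower number from compound 1 to compound 2 (1.34 log units; beyond the scatter) and in an at least 11-fold lower number from compound 1 to compound 3 (1.04 log units; beyond the scatter) alike.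

Compound 4 `CCCCCCOc1ccc(-c2c(C)[nH]c(=O)n2C)cc1` carries hexyloxy in place of hexyl on an aromatic carbon and otherwise matches compound 3. The large steps suggest that compound 4 should keep the gain that came with a chain. The closest guide is the small move a 2.0-fold higher number from compound 2 to compound 3 (0.30 log units; within the scatter) between pentyloxy and hexyl. A slight lean toward the number of compound 2 at 4500 nM seems reasonable, but no change beyond the scatter is expected. The expected move is a 1.8-fold lower number from compound 3 to compound 4 (0.26 log units; within the scatter) as estimated here. For compound 4 the estimated value is 5000 nM with 1500 nM to 15000 nM as its expected range.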

Compound 4, half-maximal inhibitory concentration: 7300 nM
Beside the measured number, compound 4's estimate is 1.5-fold (0.16 log units) below it; low and high end bracket the measured number.
By their numbers in this assay, from the lowest: compounds 2, 4 and 3 (each within the scatter of the next). At a limit, above all of these: compound 1.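

In this assay, swapping hexyl for hexyloxy on this aromatic carbon adds an oxygen and one hydrogen-bond acceptor, yet a 1.2-fold lower number from compound 3 to compound 4 (0.09 log units; within the scatter) stays inside the usual scatter, so the assay cannot tell these two chains apart. Going from pentyloxy to hexyloxy, a change of one carbon at the chain's end, gives the same kind of answer, with a 1.6-fold higher number from compound 2 to compound 4 (0.21 log units; within the scatter), so compound 2, compound 3 and compound 4 all read alike within the scatter. The large gain now appears with a third chain, as an at least 13-fold lower number from compound 1 to compound 4 (1.13 log units; beyond the scatter) joins the two earlier large steps, and its true size is unknown because compound 1 reads only as a limit: the limit of > 100000 nM in this assay, at which 1 of the 4 values shown sits.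

What the compounds shown leave open is how far chain length can vary, since a much shorter chain such as ethoxy or a longer chain such as decyloxy could behave differently from these three. From the compounds shown here alone, it is also open whether a chain ending in an amine or a carboxylic acid would keep the gain seen with these plain carbon chains.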